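From compound 3 to compound 4: bromo to methoxy

A few compounds are considered here, and "the series" means these few. Any claim that something is new, unique, unknown or untested is made for them only; others in the source may bear on it.

In an ADME assay on BJ cells (Homo sapiens) for cytotoxicity, with a stated time of 72 h (a lower number here means that less compound is needed, a higher number that more compound is needed for the effect), compound 3 (`CCc1ccc(-c2nc3c(c(C)nn3-c3ccccc3)c(-c3ccccc3Br)c2C#N)cc1`) gives > 20000 nM as a limit. It therefore stands at the limit of > 20000 nM in this assay, at which 1 of the 3 values shown sits, and has no readable number. Compound 1 (`COc1ccc(-c2nc3c(c(C)nn3-c3ccccc3)c(-c3ccccc3O)c2C#N)cc1`) gives > 23000 nM as a limit. Compound 2 (`COc1cccc(-c2nc3c(c(C)nn3-c3ccccc3)c(-c3ccccc3O)c2C#N)c1`) gives > 23000 nM as a limit too. These two stand at the limit of > 23000 nM in this assay, at which 2 of the 3 values shown sit, and so offer no number either.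

Compound 4 (`CCc1ccc(-c2nc3c(c(C)nn3-c3ccccc3)c(-c3ccccc3OC)c2C#N)cc1`) carries methoxy in place of bromo on an aromatic carbon, ortho to a large group: methoxy in place of bromo on an aromatic carbon.

Going by the values given here, the only measured step is a step that the two limits leave unreadable from compound 1 to compound 2 and it gives no size to carry over. It also concerns a different change. With compound 3 at > 20000 nM as a limit, no step beyond the scatter is expected in this assay, in either direction. Compound 4 is expected to be reported as a limit as well.

For compound 4 the estimated value is 22000 nM, with an expected range from 10000 nM to 30000 nM. The expected change is a step that the limit leaves unreadable from compound 3 to compound 4.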

Compound 4, half-maximal effective concentration: > 20000 nM
Compound 4 gave a limit, no number; the forecaster's own chance of this, stated with the estimate: 90%; the middle value does not contradict the limit.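

Compound 3 and compound 4 both stand as limits in this assay, and the step from bromo to methoxy cannot be read. The compounds shown leave open whether any change on the shared core gives a readable number in this assay, as all four values are limits.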